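The compounds below may be only part of what the source reports. "The series", "measured", "known", "first", "only" and "open" are said of these compounds alone.

Working notes on the series. Three analogues on a shared core have been read in an ADME assay on PBMC cells (Homo sapiens) for cytotoxicity; on this read-out higher numbers stand for lower toxicity in this test and lower numbers for higher toxicity in this test. Compound 1 `CC(CCNC(=O)c1c(Cl)cncc1Cl)N1CCC(C(Oc2cccc(Cl)n2)c2ccc(OC(F)(F)F)cc2)CC1` gives 6000 nM in this assay; compound 2 `CC(CCNC(=O)c1c(Cl)cncc1Cl)N1CCC(C(Oc2cccc(C#N)n2)c2ccc(C(F)(F)F)cc2)CC1` gives 15700 nM; compound 3 `Cc1cccc(OC(c2ccc(Br)cc2)C2CCN(C(C)CCNC(=O)c3c(Cl)cncc3Cl)CC2)n1` gives 6500 nM. Compound 2 holds the highest number of the three, with compound 3 nearest and compound 1 furthest, both gaps beyond the scatter, so compound 2 reads as the least toxic of the measured set in this assay.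

Compound 4 `CC(CCNC(=O)c1c(Cl)cncc1Cl)N1CCC(C(Oc2cc(Cl)ccn2)c2ccc(C(F)(F)F)cc2)CC1` is not yet measured. It differs from compound 2 in one place: 4-chloropyridin-2-yl in place of 6-cyanopyridin-2-yl on an oxygen on a saturated carbon. Among the compounds with values here, no measured pair carries this exact change, so the size of the step is uncertain. Compound 1 and compound 3 both sit well below compound 2 in this assay, and the expectation is that compound 4 moves back toward that level. The expected step is a 2.0-fold lower number from compound 2 to compound 4 (0.29 log units; within the scatter), a drop that is likely to reach beyond the scatter. Compound 4 is estimated at 8000 nM, with a range from 3500 nM to 18000 nM.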

Compound 4, half-maximal cytotoxic concentration: 4260 nM
Compound 4: the middle estimate sits 1.9-fold (0.27 log units) above what was measured; the range from low to high includes it.
By their numbers in this assay, from the lowest: compounds 4, 1 and 3 (each within the scatter of the next); then compound 2.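

In this assay, within the data shown here, the first single-place change gives a 3.7-fold lower number from compound 2 to compound 4 (0.57 log units; beyond the scatter) at the oxygen on a saturated carbon. Among these compounds, with the rest of compound 2 held fixed, exchanging 6-cyanopyridin-2-yl for 4-chloropyridin-2-yl is enough to move the number beyond the scatter, so this position matters on this read-out, something the earlier compounds, each differing in more than one place, could not show. No measured property accounts for the step, which stands as an observation on this one pair.

The change replaces nitrile with chlorine and alters the substitution pattern at once, and the compounds shown do not separate the two. Going by these compounds, how 4-cyanopyridin-2-yl or 6-aminopyridin-2-yl would read on the core of compound 2 remains open.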